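One Fluorine, Two Placements on the Amide-Side Ring

The compounds below may be only part of what the source reports. "The series", "measured", "known", "first", "only" and "open" are said of these compounds alone.

Compound 1, `Cc1c(C(=O)Nc2ccc(C(F)(F)F)cc2)cnn1-c1ccc(F)c(Cl)c1`: 1300 nM
Compound 2, `Cc1c(C(=O)Nc2ccc(OC(F)(F)F)cc2)cnn1-c1ccc(F)cc1`: 3400 nM
Compound 3, `Cc1c(C(=O)Nc2cccc(F)c2)cnn1-c1ccc(F)cc1`: 3000 nM

All three share one core and were tested in a functional assay with Homo sapiens as the target; a lower number here means a stronger inhibitor, a higher number a weaker inhibitor. Among them compound 3 stands second highest; compound 2 lies within the scatter of it, whereas compound 1 gives a number that is lower by more than the scatter. Compound 4, `Cc1c(C(=O)Nc2ccccc2F)cnn1-c1ccc(F)cc1`, has the same atoms as compound 3, joined differently: 2-fluorophenyl in place of 3-fluorophenyl on an amide-type nitrogen. Going by the values given here, no measured pair here shows this kind of change, so nothing in the data sets the size of its effect. The step is therefore expected to stay within the scatter, no change at the digits printed from compound 3 to compound 4 (within the scatter). In this assay compound 4 is expected to give about 3000 nM, with a range from 1200 nM to 8000 nM.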

Compound 4, half-maximal inhibitory concentration: 4000 nM
For compound 4 the middle estimate is 1.3-fold (0.12 log units) below the measured one, within the range that was stated.
By their numbers in this assay, from the lowest: compound 1; then compounds 3, 2 and 4 (each within the scatter of the next).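

In this assay, going by these compounds alone, 2-fluorophenyl in place of 3-fluorophenyl on the amide-type nitrogen gives a 1.3-fold higher number from compound 3 to compound 4 (0.12 log units; within the scatter) as its step, the first single-change comparison at this position. For this one pair, then, where the fluorine sits on the ring does not separate the two compounds in this assay. Nothing measured here bears on what lies behind this result.

Still open, going by these compounds, is whether a different kind of group on this ring, such as an amine or a carboxylic acid, would shift the number beyond the scatter. A single pair also cannot show whether the same swap would read alike on another core.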